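The compounds below may be only part of what the source reports. "The series", "measured", "known", "first", "only" and "open" are said of these compounds alone.

Compound 1 `N#C/C(=C/c1ccc(Cl)cc1)C(=O)c1ccc[nH]1` gives 31000 nM in a functional assay on A-431 cells (Homo sapiens) for cytotoxicity, read by MTT assay, with a stated time of 72 h; on this read-out higher numbers stand for weaker inhibition of growth and lower numbers for stronger inhibition of growth. Compound 2 `N#C/C(=C/c1ccc([N+](=O)[O-])cc1)C(=O)c1ccc[nH]1` gives only the limit < 10000 nM. Compound 3 `N#C/C(=C/c1ccc(O)cc1)C(=O)c1ccc[nH]1` gives only the limit < 10000 nM.

Compound 3 therefore stands at the limit rather than at a number, and the same holds for two of the three values shown (the limit of < 10000 nM in this assay, at which 2 of the 3 values shown sit). Against compound 1 it shows an at least 3.1-fold lower number from compound 1 to compound 3 (0.49 log units; beyond the scatter), while the step that the two limits leave unreadable from compound 2 to compound 3 cannot be read. Compound 4 `COc1ccc(/C=C(/C#N)C(=O)c2ccc[nH]2)cc1` differs from compound 3 by methyl in place of hydrogen on an oxygen on an aromatic ring. Among the measured compounds shown here, none of the measured steps touches this oxygen; all three swap groups on the aromatic carbon, so they give no direct guide. Compound 4 is expected near the limit, at about 10000 nM (range 2500 nM to 40000 nM), a step of a number no lower from compound 3 to compound 4 (the limit leaves the size open) that is estimated to stay within the scatter.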

Compound 4, concentration for 50% growth inhibition: 13000 nM
Compound 4: middle estimate off by 1.3-fold (0.11 log units), on the low side; measured number inside the range.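

Methyl in place of hydrogen on this oxygen gives a first reading of the change in this assay: an at least 1.3-fold higher number from compound 3 to compound 4 (0.11 log units; that floor lies within the scatter), a floor too small to separate methoxy from hydroxy. Methoxy in place of nitro gives an at least 1.3-fold higher number from compound 2 to compound 4 (0.11 log units; that floor lies within the scatter), which carries the same reservation. Methoxy in place of chloro gives a 2.4-fold lower number from compound 1 to compound 4 (0.38 log units; beyond the scatter), so methoxy, like nitro and hydroxy, reads lower than chloro.

From the compounds shown here alone, what a longer chain on this oxygen, such as ethoxy, or an amine on the aromatic carbon would give stays open. The true size of the steps from compound 2 and compound 3 also stays open because both rest on a limit: the limit of < 10000 nM in this assay, at which 2 of the 4 values shown sit.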